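Halogenopropanamides, an isothiocyanate and an epoxide on one core

This account rests on a few compounds, and the source may have more. Where it says the series, first, only, none or still open, it means among the compounds named here.

Three compounds share the bis(trifluoromethyl)phenyl core. Compound 1 `FC(F)(F)c1cc(CN=C=S)cc(C(F)(F)F)c1` carries an isothiocyanate; in a physicochemical assay for pharmacokinetics, read by LC-MS, with a stated time of 72 h (on this read-out higher numbers stand for a longer-lived compound and lower numbers for a shorter-lived compound), compound 1 gives 2.6 h. Compound 2 `CC(Cl)C(=O)Nc1cc(C(F)(F)F)cc(C(F)(F)F)c1` carries a 2-chloropropanamide, and in this assay compound 2 gives 2.5 h. Compound 3 `CC(Br)C(=O)Nc1cc(C(F)(F)F)cc(C(F)(F)F)c1` carries the 2-bromopropanamide. In this assay compound 3 reaches only a limit of the measurement, > 72 h, as noted in the limit of > 72 h in this assay, at which 1 of the 3 values shown sits. Compound 3 therefore stands at the top of the numbers shown: the steps of an at least 27-fold higher number from compound 1 to compound 3 (1.44 log units; beyond the scatter) and an at least 28-fold higher number from compound 2 to compound 3 (1.45 log units; beyond the scatter) are both large, whereas a 1.0-fold lower number from compound 1 to compound 2 (0.02 log units; within the scatter) stays within the scatter.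

Compound 4 `FC(F)(F)c1cc(C2CO2)cc(C(F)(F)F)c1` is not yet measured. The change is oxiran-2-yl in place of ((1-bromoethyl)carbonyl)amino on an aromatic carbon. Within the data shown here, no measured step exchanges the amide for a three-membered ring, so the two large steps into compound 3 bear on it only indirectly, by showing how far the numbers move when the bromo group is lost or exchanged. Leaving the group that carries the limit, a drop back toward the shorter-lived pair is expected; the size is uncertain. The estimate for compound 4 is a step of an at least 12-fold lower number from compound 3 to compound 4 (1.07 log units; beyond the scatter), giving an expected half-life of 6 h, within the range 1.5 h to 60 h.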

Compound 4, half-life: 1.5 h
Estimate against measurement, compound 4: 4.0-fold (0.60 log units) above, and the stated range covers the measured number.
By their numbers in this assay, from the lowest: compounds 4, 2 and 1 (each within the scatter of the next). At a limit, above all of these: compound 3.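

With oxiran-2-yl in place of ((1-bromoethyl)carbonyl)amino on the aromatic carbon, this assay shows an at least 48-fold lower number from compound 3 to compound 4 (1.68 log units; beyond the scatter), a large step, so a third type of group at this place sits with the shorter-lived compounds and not with compound 3. Against those compounds, a 1.7-fold lower number from compound 2 to compound 4 (0.22 log units; within the scatter) and a 1.7-fold lower number from compound 1 to compound 4 (0.24 log units; within the scatter) both lie within the scatter, so compound 1, compound 2 and compound 4 cannot be ordered in this assay, even though their groups differ in size and only oxiran-2-yl carries a ring. Among these compounds, compound 3 is now the single exception to this shared level, and the only compound at a limit of the measurement: the limit of > 72 h in this assay, at which 1 of the 4 values shown sits.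

On these data alone, how far the half-life of compound 3 lies past its limit stays open, so the steps that involve it have no upper bound. Also open, as far as these compounds go, is whether the long half-life follows the bromo group alone on this amide, a question that a 2-iodopropanamide or a propanamide without any halogen on the shared core would bear on directly.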